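The compounds below may be only part of what the source reports. "The series", "measured", "known", "first", "only" and "open" are said of these compounds alone.

Compound 1 `O=C(NO)c1cc(-c2ccccc2)nn1Cc1ccccc1` opens this small series. In a functional assay on A549 cells (Homo sapiens) for inhibition, read by sulforhodamine B assay, with a stated time of 48 h (a lower number here means a stronger inhibitor, a higher number a weaker inhibitor), compound 1 gives 5600 nM. Compound 2 `CC(C)(C)c1ccc(Cn2nc(-c3ccccc3)cc2C(=O)NO)cc1` carries tert-butyl in place of hydrogen on an aromatic carbon, and in this assay compound 2 gives 1720 nM, a step that reads a 3.3-fold lower number from compound 1 to compound 2 (0.51 log units; beyond the scatter). Compound 3 `COc1ccc(-c2cc(C(=O)NO)n(Cc3ccccc3)n2)cc1` differs from compound 1 in its core by methoxy in place of hydrogen on an aromatic carbon; in this assay compound 3 gives 6770 nM, which is a 1.2-fold higher number from compound 1 to compound 3 (0.08 log units; within the scatter). Compound 4 `COc1ccc(-c2cc(C(=O)NO)n(Cc3ccc(C(C)(C)C)cc3)n2)cc1` has not been measured yet. It is reached from compound 3 by tert-butyl in place of hydrogen on an aromatic carbon, the same change, at the same kind of place, that carries compound 1 to compound 2. For compound 4 the expected step is a 3.2-fold lower number from compound 3 to compound 4 (0.51 log units; beyond the scatter), resting on the earlier 3.3-fold lower number from compound 1 to compound 2 (0.51 log units; beyond the scatter). Compound 4 is therefore estimated at 2100 nM, between 1000 nM and 4500 nM.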

Compound 4, half-maximal inhibitory concentration: 2560 nM
Compound 4: the middle estimate sits 1.2-fold (0.09 log units) below what was measured; measured number inside the range.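

In this assay the tert-butyl change carries over from one core to the other, giving a 2.6-fold lower number from compound 3 to compound 4 (0.42 log units; beyond the scatter), much like the earlier step: the same change on two cores in this assay, a 3.3-fold lower number (0.51 log units; beyond the scatter) from compound 1 to compound 2 and a 2.6-fold lower number (0.42 log units; beyond the scatter) from compound 3 to compound 4, 1.2-fold (0.09 log units) apart, within the scatter of two such steps. The methoxy change, which gives a 1.5-fold higher number from compound 2 to compound 4 (0.17 log units; within the scatter), stays within the scatter on both cores: the same change on two cores in this assay, a 1.2-fold higher number (0.08 log units; within the scatter) from compound 1 to compound 3 and a 1.5-fold higher number (0.17 log units; within the scatter) from compound 2 to compound 4, 1.2-fold (0.09 log units) apart, within the scatter of two such steps. Each comparison rests on just two pairs of compounds in a single cell assay, so the two changes are shown to add up consistently here, but not on any other core or with any other group.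

The compounds shown leave open how an amine or a chlorine atom on these aromatic rings would act. They also leave open whether the tert-butyl step would hold with a carboxylic acid in place of the methoxy.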